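Same Swap on a Second Core: An Expectation

This account rests on a few compounds, and the source may have more. Where it says the series, first, only, none or still open, it means among the compounds named here.

Measured so far:
compound 1 `COc1ccc(Cl)cc1C(=O)NCC1CCN(S(=O)(=O)NC(=O)NC2CCCCC2)CC1` gives 20%
compound 2 `COc1ccc(Cl)cc1C(=O)NCC1CCN(S(=O)(=O)NC(=O)NC[C@@H]2C[C@@H]3C=C[C@@H]2C3)CC1` gives 15%
compound 3 `O=C(NC1CCCCC1)NS(=O)(=O)N1CCC(CCNC(=O)C(F)(F)F)CC1` gives 13%

All three compounds were tested in a functional assay on the whole organism (blood) with Rattus norvegicus as the target, with stated times of 24 h and 1 h, at a dose of 5 mg/kg by the intraperitoneal route; a higher number here means a stronger effect of the compound at the dose given, a lower number a weaker effect. Compound 1 gives 20% and compound 2 gives 15%. The two differ by one change, (a group of 8 heavy atoms (8 carbon; 2 five-membered non-aromatic rings of carbon only) in place of a group of 6 heavy atoms (6 carbon; one six-membered non-aromatic ring of carbon only), on an amide-type nitrogen), and this change made a number 5 percentage points lower from compound 1 to compound 2 (within the scatter), so the two values cannot be told apart. Compound 3 gives 13% in this assay. Its value, that of compound 2 and that of compound 1 all lie within the scatter of one another, so none of the three stands out. How the core of compound 3 differs from that of compound 1 is not broken down here.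

Compound 4 `O=C(NC[C@@H]1C[C@@H]2C=C[C@@H]1C2)NS(=O)(=O)N1CCC(CCNC(=O)C(F)(F)F)CC1` has not yet been measured. It arises from compound 3 through (a group of 8 heavy atoms (8 carbon; 2 five-membered non-aromatic rings of carbon only) in place of a group of 6 heavy atoms (6 carbon; one six-membered non-aromatic ring of carbon only), on an amide-type nitrogen), which is the same change that turns compound 1 into compound 2, on the same kind of nitrogen with the same neighbours. Within the data shown here, the only guide is the earlier pair, which showed a step within the scatter. The step is therefore expected to be a number 3 percentage points lower from compound 3 to compound 4 (within the scatter), because the same change earlier gave a number 5 percentage points lower from compound 1 to compound 2 (within the scatter). On that basis, compound 4 is estimated to give 10% in this assay, with a likely range from 2% to 22%.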

Compound 4, a percentage reported as activity, at one dose (the size of the read-out at that dose, not a potency): 22%
For compound 4 the middle estimate is 12 percentage points below the measured one, within the range that was stated.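

In this assay, putting the two-ring group with its double bond in place of cyclohexyl on the amide-type nitrogen gives a number 9 percentage points higher from compound 3 to compound 4 (within the scatter), so on this core the swap cannot be told apart from repeat-to-repeat variation. Set beside the same swap on the other core, the two steps cannot be told apart from each other either: the same change on two cores in this assay, a number 5 percentage points lower (within the scatter) from compound 1 to compound 2 and a number 9 percentage points higher (within the scatter) from compound 3 to compound 4, 14 percentage points apart, within the scatter of two such steps. This shows that neither of the two pairs gives a reliable effect of the swap and that the pairs do not disagree, but it does not show that the swap is truly without effect or that it would behave alike on a further core, since two small steps read at a single dose can hide a modest real difference in either direction.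

The compounds shown carry only cyclohexyl or this one two-ring group at that nitrogen, so it remains open how an aromatic phenyl ring or a straight hexyl chain would read there. From the compounds shown here alone, it also remains open whether the double bond of the entering group matters, which the fully saturated version of the same two-ring group could help to settle.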